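The source may report more compounds than this note shows. Statements on the series, on what has been measured and on what is new or still open speak of the compounds shown alone.

Compounds measured so far:

compound 1, `Cn1nc(-c2nnc(SCc3cccc(Cl)c3Cl)o2)cc1-c1ccc(C(F)(F)F)cc1`, 36800 nM
compound 2, `Cn1nc(-c2nnc(SCc3ccc(C(F)(F)F)cc3)o2)cc1-c1ccc(C(F)(F)F)cc1`, 20500 nM
compound 3, `Cn1nc(-c2ccc(C(F)(F)F)cc2)cc1-c1nnc(SCc2cccc(Cl)c2Cl)o1`, 56500 nM

All three were tested in a functional assay on Ehrlich cells (Mus musculus) for cytotoxicity, read by MTT assay, with a stated time of 24 h; on this read-out higher numbers stand for weaker inhibition and lower numbers for stronger inhibition. Compound 1 and compound 2 share one core; compound 3 is built from the same atoms as compound 1, joined differently, and the difference between the two cores is not broken down here. Among the three, compound 3 has the highest number in this assay, but its gap to compound 1 lies within the scatter, while its gap to compound 2 lies beyond it.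

The change from compound 1 to compound 2 is 4-(trifluoromethyl)phenyl in place of 2,3-dichlorophenyl on a saturated chain carbon bound to a sulfur. In this assay it gave a 1.8-fold lower number from compound 1 to compound 2 (0.25 log units; within the scatter).

Compound 4, `Cn1nc(-c2ccc(C(F)(F)F)cc2)cc1-c1nnc(SCc2ccc(C(F)(F)F)cc2)o1`, has not yet been measured. It differs from compound 3 by 4-(trifluoromethyl)phenyl in place of 2,3-dichlorophenyl on a saturated chain carbon bound to a sulfur. The place of the change reads the same in both pairs, so this is the same change applied to the core of compound 3 instead of the core of compound 1.

Among the compounds with values here, since the one measured example of this change, from compound 1 to compound 2, moved the number by an amount that stayed within the scatter, a step of similar size is expected here, and compound 4 is therefore expected to show a 1.8-fold lower number from compound 3 to compound 4 (0.26 log units; within the scatter). On that basis compound 4 is estimated at 31000 nM in this assay, most likely between 14000 nM and 70000 nM.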

Compound 4, half-maximal inhibitory concentration: 27300 nM
Compound 4: middle estimate off by 1.1-fold (0.06 log units), on the high side, within the range that was stated.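

In this assay, 4-(trifluoromethyl)phenyl in place of 2,3-dichlorophenyl on the core of compound 3 gave a 2.1-fold lower number from compound 3 to compound 4 (0.32 log units; beyond the scatter). Set beside the earlier step, the change carried from one core to the other in the same direction and at a similar size, and the two steps cannot be told apart: the same change on two cores in this assay, a 1.8-fold lower number (0.25 log units; within the scatter) from compound 1 to compound 2 and a 2.1-fold lower number (0.32 log units; beyond the scatter) from compound 3 to compound 4, 1.2-fold (0.06 log units) apart, within the scatter of two such steps. Within the data shown here, that one step is printed as within the scatter and the other as beyond it therefore marks no real difference between the cores, but the result rests on only two pairs and one exchange of groups in a single assay, so it neither shows that other changes would carry over in the same way nor explains why this one did.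

The compounds shown place only 2,3-dichlorobenzyl and 4-(trifluoromethyl)benzyl on the sulfur, so it remains open whether a benzyl group bearing an amine or a carboxylic acid, or a longer chain in place of the benzyl group, would give similar steps on the two cores. Going by these compounds, it also remains open whether the same steps would appear on cells other than those used in this assay.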